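Series notes: from compound 2 to compound 3

The source may report more compounds than this note shows. Statements on the series, on what has been measured and on what is new or still open speak of the compounds shown alone.

Measured so far:
compound 1 `Cc1cc(C)c(CN2CCc3c(Cl)cc(C(CO)C4CCOC4)c(Cl)c3C2=O)c(=O)[nH]1` (2.1; 2.1 (2 entries))
compound 2 `Cc1cc(C)c(CN2CCc3c(Cl)cc(-c4c(C)noc4C)c(Cl)c3C2=O)c(=O)[nH]1` (3.1)

Among the measured compounds shown here, in a physicochemical assay for lipophilicity, at pH 7.4 (on this read-out lower numbers stand for lower lipophilicity and higher numbers for higher lipophilicity), compound 2 stands at 3.1 on a single entry, and that is the only single number available. Compound 1 lies lower at 2.1; 2.1 (2 entries) over two entries.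

Compound 3 `Cc1cc(C)c(CN2CCc3c(Cl)cc([C@@H](CO)[C@H]4CCCO4)c(Cl)c3C2=O)c(=O)[nH]1` differs from compound 2 in one group (a group of 8 heavy atoms (6 carbon, 2 oxygen; one five-membered non-aromatic ring with 1 hetero atom) in place of a group of 7 heavy atoms (5 carbon, 1 nitrogen, 1 oxygen; one five-membered aromatic ring with 2 hetero atoms), on an aromatic carbon) on an aromatic carbon ortho to a chloro group. For the measured compounds named here, no step between measured compounds differing in one place is available, so the expectation rests on the two values alone. Compound 1 also carries a five-membered non-aromatic ring at this place and reads 2.1; 2.1 (2 entries) in contrast to compound 2 at 3.1 in the same measurement. A downward move in this assay beyond the scatter is therefore expected, with a number 1.00 log units lower from compound 2 to compound 3 (beyond the scatter) as the estimated step. For compound 3 the expected value is 2.1 (estimated range 1.7 to 2.5).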

Compound 3, distribution coefficient: 2.5
Estimate against measurement, compound 3: 0.40 log units below, within the range that was stated.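

In this assay, the position on the aromatic carbon ortho to a chloro group now has its first readable step: putting the group of 8 heavy atoms with a five-membered non-aromatic ring in place of 3,5-dimethyl-1,2-oxazol-4-yl gives a number 0.60 log units lower from compound 2 to compound 3 (beyond the scatter). The two non-aromatic groups at this place also stay apart on the printed values, with compound 3 at 2.5 and compound 1 at 2.1; 2.1 (2 entries), so the read-out at this position is not fixed by the presence of a non-aromatic ring alone. The step from the aromatic group changes several things at once (the ring type, the hydrogen-bond donor count and the 2 defined stereocentres), and no measurement shown here assigns the shift to any one of them.

The compounds shown leave open how much of the shift would remain with a single change at this place, for example a plain tetrahydrofuran ring without the hydroxymethyl arm, or with the other stereoisomers of compound 3. They also leave open how a charged group such as a carboxylic acid or a tertiary amine at this position would read in this assay.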